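Ethyl Carbamate in Place of the Pyridinyl Carbamate

This account rests on a few compounds, and the source may have more. Where it says the series, first, only, none or still open, it means among the compounds named here.

Three carbamates sharing the same core have been measured in an assay on frontal cortex for displacement of a labelled ligand from corticotropin-releasing factor receptor 1 (Rattus norvegicus), with a stated time of 2 h; a lower number here means a stronger inhibitor, a higher number a weaker inhibitor. Compound 1 `COc1nc(C)c(Nc2nc(Cl)cn([C@H](COC(=O)Nc3ccccc3)C3CC3)c2=O)cc1C` gives 1.5 nM, and compound 2 `COc1nc(C)c(Nc2nc(Cl)cn([C@H](COC(=O)Nc3cccc(C#N)c3)C3CC3)c2=O)cc1C` gives 1.3 nM; the step of a 1.2-fold lower number from compound 1 to compound 2 (0.06 log units; within the scatter) brings cyano in place of hydrogen on an aromatic carbon and stays within the scatter. Compound 3 `COc1ccc(NC(=O)OC[C@H](C2CC2)n2cc(Cl)nc(Nc3cc(C)c(OC)nc3C)c2=O)c(C)n1` gives 9.2 nM, the highest of the three numbers: the step of a 6.1-fold higher number from compound 1 to compound 3 (0.79 log units; beyond the scatter) and the step of a 7.1-fold higher number from compound 2 to compound 3 (0.85 log units; beyond the scatter) both exchange the aryl group on the amide-type nitrogen and both lie beyond the scatter, though only modestly.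

Compound 4 `CCNC(=O)OC[C@H](C1CC1)n1cc(Cl)nc(Nc2cc(C)c(OC)nc2C)c1=O` is not yet measured. Its difference from compound 3 is ethyl in place of 6-methoxy-2-methylpyridin-3-yl on an amide-type nitrogen. Among the measured compounds shown here, no measured step removes the aromatic ring from this nitrogen altogether; the two steps that touch the same position only exchange one aryl group for another, and they were modest in size. Compound 3 already stands at the weak end of the series, and with an ethyl group in its place the expectation is a further modest rise in this assay, as a 2.7-fold higher number from compound 3 to compound 4 (0.43 log units; beyond the scatter), with wide uncertainty. Compound 4 is therefore estimated at 25 nM, in a range from 5 nM to 120 nM.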

Compound 4, half-maximal inhibitory concentration: 14 nM
For compound 4 the middle estimate is 1.8-fold (0.25 log units) above the measured one; the measured number falls inside the stated range.
By their numbers in this assay, from the lowest: compounds 2 and 1 (each within the scatter of the next); then compounds 3 and 4 (each within the scatter of the next).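

In this assay, an aromatic ring on the amide-type nitrogen proves not to be required to reach the level of compound 3: the step of a 1.5-fold higher number from compound 3 to compound 4 (0.18 log units; within the scatter) puts ethyl in place of 6-methoxy-2-methylpyridin-3-yl and stays within the scatter, so these two groups cannot be told apart at this position. Ethyl does not match the other two aryl groups, however: the step of an 11-fold higher number from compound 2 to compound 4 (1.03 log units; beyond the scatter) is large and the step of a 9.3-fold higher number from compound 1 to compound 4 (0.97 log units; beyond the scatter) is modest, both beyond the scatter, so the low numbers belong to 3-cyanophenyl and phenyl and not to every aromatic ring on this nitrogen, as compound 3 carries a ring and still stands level with compound 4. No evidence at hand accounts for this difference among the groups.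

The compounds shown leave open whether a longer chain such as butyl, or a benzyl group, on this nitrogen would stay with compound 4 or come nearer to compound 1. They also leave open whether the methoxy or the methyl on the pyridinyl group is what separates compound 3 from compound 1.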